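Methyl on the aromatic nitrogen of compound 3

The compounds below may be only part of what the source reports. "The series", "measured", "known", "first", "only" and "open" are said of these compounds alone.

Measured in a functional assay on HeLa cells (Homo sapiens) for antiproliferative activity, read by MTT assay, with a stated time of 48 h; a higher number here means a weaker inhibitor, a lower number a stronger inhibitor:
- compound 1 `CCCn1c(N)c(-c2nc3ccccc3[nH]2)c2nc(C#N)c(C#N)nc21`: > 50000 nM (a limit)
- compound 2 `N#Cc1nc2c(-c3nc4ccccc4[nH]3)c(N)n(CCCO)c2nc1C#N`: > 50000 nM (a limit)
- compound 3 `CCN(CC)CCCCn1c(N)c(-c2nc3ccccc3[nH]2)c2nc(C#N)c(C#N)nc21`: 10100 nM

Among the compounds with values here, compound 3 holds the only true number, 10100 nM. The other two stand at the limit of > 50000 nM in this assay, at which 2 of the 3 values shown sit.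

Next is compound 4 `CCN(CC)CCCCn1c(N)c(-c2nc3ccccc3n2C)c2nc(C#N)c(C#N)nc21`, with methyl in place of hydrogen on an aromatic nitrogen.

The measured steps, an at least 4.9-fold lower number from compound 1 to compound 3 (0.69 log units; beyond the scatter) and an at least 4.9-fold lower number from compound 2 to compound 3 (0.69 log units; beyond the scatter), both lie on the saturated chain, and compound 4 keeps that chain. Within the data shown here, no measured step touches the aromatic nitrogen, so no shift beyond the scatter is expected in this assay.

The expected outcome is a 1.2-fold higher number from compound 3 to compound 4 (0.07 log units; within the scatter).

For compound 4 the estimate is 12000 nM, with an expected range of 4000 nM to 40000 nM.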

Compound 4, half-maximal inhibitory concentration: 1610 nM
Estimate against measurement, compound 4: 7.5-fold (0.87 log units) above; measured number outside the range, below it.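

In this assay, 1-methyl-1H-benzimidazol-2-yl in place of 1H-benzimidazol-2-yl gives a 6.3-fold lower number from compound 3 to compound 4 (0.80 log units; beyond the scatter), so the aromatic nitrogen, and not only the saturated chain, moves the number. This is the first step in the series read between two true numbers, since the earlier readable steps rest on a limit: the limit of > 50000 nM in this assay, at which 2 of the 4 values shown sit.
Nothing measured here accounts for the change.
As far as these compounds go, whether ethyl or acetyl on this nitrogen goes the same way remains open. Also open, from the compounds shown here alone, is whether methyl here has the same effect on the chains of compound 1 and compound 2.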